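The compounds below may be only part of what the source reports. "The series", "measured", "known", "first", "only" and "open" are said of these compounds alone.

Working notes on the series. Two members have numbers in a functional assay on A498 cells (Homo sapiens) for antiproliferative activity, read by sulforhodamine B assay, with a stated time of 48 h; on this read-out lower numbers stand for stronger inhibition of growth and higher numbers for weaker inhibition of growth. Compound 1, `COc1ccc(OC)c(/C=C/c2nnc(Nc3ccc(Cl)cc3)o2)c1`, gives 7760 nM. Compound 2, `COc1ccc(OC)c(/C=C/C(=O)N/N=C/c2ccc(Cl)cc2)c1`, gives 27500 nM, the highest of the two numbers and beyond the scatter from compound 1, so compound 2 shows the weaker growth inhibition of the pair.

The next member, compound 3, `COc1ccc(OC)c(/C=C/C(=O)N/N=C/c2ccccc2)c1`, is not yet measured. It differs from compound 2 by hydrogen in place of chloro on an aromatic carbon. Going by the values given here, no measured pair shows this kind of change, so nothing on record fixes its size or direction. The expectation is that the step from compound 2 to compound 3 is small, not beyond the scatter, with a lean toward a slightly higher number, and the estimated step is a 1.3-fold higher number from compound 2 to compound 3 (0.10 log units; within the scatter). Compound 3 is therefore expected to give about 35000 nM in this assay, within the range 12000 nM to 100000 nM.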

Compound 3, concentration for total growth inhibition: > 100000 nM
Compound 3: a limit, no number (the forecaster's own chance of this, stated with the estimate: 15%); at least 2.8-fold (0.45 log units) between middle value and limit.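

In this assay the series now has its first step between compounds that differ in one place, and replacing chloro with hydrogen on this aromatic carbon, para to a large group, gives an at least 3.6-fold higher number from compound 2 to compound 3 (0.56 log units; beyond the scatter). Compound 3 gives > 100000 nM, which is a limit of the assay and not a number. The chloro at this position therefore matters for growth inhibition in this pair, while the full size of the step stays unfixed: the limit of > 100000 nM in this assay, at which 1 of the 3 values shown sits.

As far as these compounds go, only chloro and hydrogen appear at this place, so it remains open whether the effect is specific to chloro or would also be seen with fluoro, methyl or methoxy there. From the compounds shown here alone, it also remains open whether the 4-chlorophenyl to phenyl change would act in the same way on the core of compound 1.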